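The compounds below may be only part of what the source reports. "The series", "measured", "known", "first", "only" and "open" are said of these compounds alone.

Measured in a functional assay on HeLa cells (Homo sapiens) for cytotoxicity, read by MTT assay, with a stated time of 24 h; a lower number here means a stronger inhibitor, a higher number a weaker inhibitor:
compound 1 `COc1cc(/C=C2\CN(C)C/C(=C\c3ccc(Cl)cc3)C2=O)cc(OC)c1`: 11200 nM
compound 2 `COc1cc(/C=C2\CN(C)C/C(=C\c3ccc(Br)cc3)C2=O)cc(OC)c1`: 5900 nM
compound 3 `CN1C/C(=C\c2ccc(Cl)cc2)C(=O)/C(=C/c2cccc([N+](=O)[O-])c2)C1`: a limit of the assay, > 20000 nM

Compound 1 and compound 2 differ by bromo in place of chloro on an aromatic carbon; the step between them is a 1.9-fold lower number from compound 1 to compound 2 (0.28 log units; within the scatter). The difference between the core of compound 1 and the core of compound 3 is not broken down here. Compound 3 stands at the limit of > 20000 nM in this assay, at which 1 of the 3 values shown sits.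

Compound 4 `CN1C/C(=C\c2ccc(Br)cc2)C(=O)/C(=C/c2cccc([N+](=O)[O-])c2)C1` is not yet measured in this assay. It differs from compound 3 by bromo in place of chloro on an aromatic carbon, the same change as between compound 1 and compound 2, at the same kind of place.

For compound 4 the expected step is a number no higher from compound 3 to compound 4 (the limit leaves the size open), since the same change gave a 1.9-fold lower number from compound 1 to compound 2 (0.28 log units; within the scatter), which lies within the scatter. Because compound 3 gives only > 20000 nM, compound 4 may again be reported only as a limit. The estimate for compound 4 is 20000 nM, expected between 9000 nM and 45000 nM.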

Compound 4, half-maximal inhibitory concentration: 11900 nM
The estimate for compound 4 lay 1.7-fold (0.23 log units) above the measured number, within the range that was stated.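

In this assay, bromo in place of chloro gives an at least 1.6-fold lower number from compound 3 to compound 4 (0.22 log units; that floor lies within the scatter), so on the core of compound 3 the number does not go the opposite way. Set beside the earlier step, the change reads: the same change on two cores in this assay, a 1.9-fold lower number (0.28 log units; within the scatter) from compound 1 to compound 2 and an at least 1.6-fold lower number (0.22 log units; that floor lies within the scatter) from compound 3 to compound 4; the limit leaves it open whether they differ. The true size of the step on that core stays unread, and neither core shows an effect of bromo beyond the scatter; compound 3 itself is only a limit, not a number: the limit of > 20000 nM in this assay, at which 1 of the 4 values shown sits.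

The compounds shown leave open whether fluoro or an amine in the same place would move the number beyond the scatter. Also open, on these data alone, is how this change behaves when the nitro group gives way to a nitrile or a carboxylic acid.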